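Thiosemicarbazone series: cytotoxicity and a 2-chlorophenyl analogue

The compounds below may be only part of what the source reports. "The series", "measured", "known", "first", "only" and "open" are said of these compounds alone.

Measured compounds:
- compound 1, `CC1=CC[C@@H]([C@@](C)(O)CCCC(C)(C)NC(=S)NN)CC1`; in a functional assay on MCF7 cells (Homo sapiens) for cytotoxicity, read by sulforhodamine B assay (a lower number here means that less compound is tolerated, a higher number that more compound is tolerated), compound 1 gives only a limit, > 100000 nM.
- compound 2, `CC1=CC[C@@H]([C@@](C)(O)CCCC(C)(C)NC(=S)N/N=C\c2ccc(C)cc2)CC1`; in this assay compound 2 likewise gives only a limit, > 100000 nM.
- compound 3, `CC1=CC[C@@H]([C@@](C)(O)CCCC(C)(C)NC(=S)N/N=C\c2cccc([N+](=O)[O-])c2)CC1`; in this assay compound 3 gives 47300 nM.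

Among the compounds with values here, compound 3 holds the only real number in the set; the other two values sit at the limit of > 100000 nM in this assay, at which 2 of the 3 values shown sit. The step that the two limits leave unreadable from compound 1 to compound 2 lies between two limits and cannot be read. Within the data shown here, the step of an at least 2.1-fold lower number from compound 2 to compound 3 (0.32 log units; beyond the scatter) is the one readable step, and it goes toward a lower number.

Compound 4, `CC1=CC[C@@H]([C@@](C)(O)CCCC(C)(C)NC(=S)N/N=C\c2ccccc2Cl)CC1`, differs from compound 3 by 2-chlorophenyl in place of 3-nitrophenyl on a carbon with a double bond to nitrogen. Among the measured compounds shown here, only the step of an at least 2.1-fold lower number from compound 2 to compound 3 (0.32 log units; beyond the scatter) bears on this change: there a 4-methylphenyl gave way to the 3-nitrophenyl, and the number fell beyond the scatter. Compound 4 carries a halogenated ring rather than the nitro-bearing one, so a drift back toward the earlier limit is expected, of a size near a 1.7-fold higher number from compound 3 to compound 4 (0.23 log units; within the scatter), with a real chance of a limit only. For compound 4 the estimate in this assay is 80000 nM, within 35000 nM to 150000 nM.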

Compound 4, concentration lethal to 50% of the cells: > 100000 nM
Compound 4 gave a limit, no number (the forecaster's own chance of this, stated with the estimate: 45%); middle value at least 1.2-fold (0.09 log units) away from the limit.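

In this assay, 2-chlorophenyl in place of 3-nitrophenyl on a carbon with a double bond to nitrogen gives an at least 2.1-fold higher number from compound 3 to compound 4 (0.32 log units; beyond the scatter); the value for compound 4 is a limit, which leaves this step readable only as a minimum. The 3-nitrophenyl of compound 3 now stands apart from two different rings, 4-methylphenyl and 2-chlorophenyl, rather than from one alone. The steps from compound 1 and from compound 2 to compound 4 join two limits and cannot be read, and the series now gathers at one ceiling: the limit of > 100000 nM in this assay, at which 3 of the 4 values shown sit.

As far as these compounds go, whether the nitro group itself carries the difference stays open, and a phenyl ring bearing a nitrile or a carboxylic acid at this position would bear on that question. Within the data shown here, with only one real number, the rings at the limit cannot be ranked against one another.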